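The compounds below may be only part of what the source reports. "The series", "measured", "known", "first", "only" and "open" are said of these compounds alone.

Compound 3 `c1ccc(-c2ccccc2NCC2=NCCN2)nc1` gives 30.2 nM in a functional assay for activation of Alpha-1B adrenergic receptor (Homo sapiens), read by calcium flux (a lower number here means that less compound is needed, a higher number that more compound is needed for the effect), the lowest of the two numbers shown. Compound 1 `Cc1cc(-c2ccccc2NCC2=NCCN2)on1` gives 95.5 nM in this assay, and the step of a 3.2-fold lower number from compound 1 to compound 3 (0.50 log units; beyond the scatter) is modest. Compound 2 `c1ccc(-c2cnoc2)c(NCC2=NCCN2)c1` reaches only a limit in this assay, < 100000 nM (the limit of < 100000 nM in this assay, at which 1 of the 3 values shown sits), so the steps a step that the limit leaves unreadable from compound 1 to compound 2 and a step that the limit leaves unreadable from compound 2 to compound 3 cannot be sized. Compound 4 `CO/N=C/c1ccccc1NCC1=NCCN1` differs from compound 3 by a group of 4 heavy atoms (2 carbon, 1 nitrogen, 1 oxygen; no ring) in place of a group of 6 heavy atoms (5 carbon, 1 nitrogen; one six-membered aromatic ring with 1 hetero atom), on an aromatic carbon. Among the measured compounds shown here, the only readable step swaps one ring for another; here a ring leaves altogether, and the unreadable steps show that a ring change can remove measurable activity. Compound 4 is therefore expected to need more compound, with the step of a 9.9-fold higher number from compound 3 to compound 4 (1.00 log units; beyond the scatter) in this assay. Compound 4 is estimated at 300 nM, between 60 nM and 3000 nM.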

Compound 4, half-maximal effective concentration: < 5020 nM
Compound 4: a limit, no number; the forecaster's own chance of this, stated with the estimate: 15%; the middle value is on the limit's open side.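

Compound 4 reaches only a limit, < 5020 nM, in this assay, so its steps from compound 1, compound 2 and compound 3 cannot be read. The compounds shown leave open how far the number moves when the ring leaves.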